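The source may hold more compounds than are shown below. What is called first, only, known or untested is meant among the compounds shown, and "the series" means these compounds.

Working notes on the series. In a functional assay for inhibition, with Rattus norvegicus as the target (a higher number here means a weaker inhibitor, a lower number a stronger inhibitor), compound 1 `CCc1cc(C#N)ccc1Nc1c(N[C@H](C)CC(C)(C)C)c(=O)c1=O` gives 90 nM. Compound 2 `CC(C)(C)CCNC1C(=O)C(=O)C1Cc1ccc(C#N)cc1` stands at > 30000 nM in this assay, and this reading is a limit of the assay and not a number. For compound 2 the record therefore shows (the limit of > 30000 nM in this assay, at which 1 of the 2 values shown sits).

Compound 3 `COc1ccc(CC2C(=O)C(=O)C2NCCC(C)(C)C)cc1` departs from compound 2 at one place, with methoxy in place of cyano on an aromatic carbon, para to a large group: methoxy in place of cyano on an aromatic carbon. Among the compounds with values here, no measured pair isolates this swap, so the size of the step cannot be read from the data. The expectation is for no change beyond the scatter in this assay, with no direction favoured, and another limit reading is the likeliest result. Within the data shown here, this expectation rests on compound 2 at > 30000 nM, the only measured compound that carries the same core as compound 3. The expected change is a number no higher from compound 2 to compound 3 (the limit leaves the size open). Compound 3 is estimated at 30000 nM, with an expected range from 8000 nM to 60000 nM.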

Compound 3, half-maximal inhibitory concentration: > 30000 nM
Compound 3 ended at the assay's limit (the forecaster's own chance of this, stated with the estimate: 75%); the middle value sits exactly at the limit.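

Compound 2 and compound 3 both read as limits in this assay and not as numbers, so no step can be read between them, and the swap of cyano for methoxy has no measurable size here. The compounds shown leave open what effect this swap would have on a core giving a readable number.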